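The source may report more compounds than this note shows. Statements on the series, on what has been measured and on what is new or still open speak of the compounds shown alone.

In an ADME assay on HOS cells (Homo sapiens) for cytotoxicity (a higher number here means that more compound is tolerated, a lower number that less compound is tolerated), compound 3 (`CN(Cc1nc2cccc(CN)c2[nH]1)C1CCCc2cccnc21`) gives > 20000 nM, which is a limit of the assay and not a number. Compound 2 (`CN(Cc1nc2ccccc2n1CCCNC(=N)N)C1CCCc2cccnc21`) gives > 20000 nM, which is also a limit. Compound 1 (`CN(C)CCCn1c(CN(C)C2CCCc3cccnc32)nc2ccccc21`) gives a true number, 16800 nM. Compound 3 therefore stands at the limit of > 20000 nM in this assay, at which 2 of the 3 values shown sit, with no exact place on the scale.

Compound 4 (`CN(C)CCCc1cccc2nc(CN(C)C3CCCc4cccnc43)[nH]c12`) differs from compound 3 by one change: 2-(dimethylamino)ethyl in place of amino on a saturated chain carbon bound to an aromatic carbon. Cut one bond further out, this reads aminomethyl to 3-(dimethylamino)propyl. For the measured compounds named here, the one measured step that bears on it is an at least 1.1-fold higher number from compound 1 to compound 2 (0.07 log units; that floor lies within the scatter), and that step does not go beyond the scatter. It shows what happens when compound 1 loses the dimethylamino end of its chain. Compound 1 also carries 3-(dimethylamino)propyl, and its 16800 nM is the best guide, so compound 4 is expected to lie close to that value. The expected change is an at least 1.3-fold lower number from compound 3 to compound 4 (0.12 log units; that floor lies within the scatter). For compound 4 the estimate is 15000 nM, with an expected range from 7000 nM to 25000 nM.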

Compound 4, half-maximal cytotoxic concentration: 7500 nM
The estimate for compound 4 lay 2.0-fold (0.30 log units) above the measured number; the measured number falls inside the stated range.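

In this assay, putting 2-(dimethylamino)ethyl in place of amino on a saturated chain carbon bound to an aromatic carbon gives an at least 2.6-fold lower number from compound 3 to compound 4 (0.42 log units; beyond the scatter). This is the first step shown that lies beyond the scatter, so a change at this place can lower the number that the cells tolerate, while the earlier step stayed within the scatter. The true size of the new step may be larger, since the value of compound 3 is a limit and not a number: the limit of > 20000 nM in this assay, at which 2 of the 4 values shown sit.

Going by these compounds, it remains open whether the step follows the added chain length or the two methyl groups on the nitrogen, and a plain primary amine at the end of the same chain, as in 3-aminopropyl, would separate the two. A carboxylic acid on the same saturated chain carbon also remains untested among the compounds shown here.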